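Unsaturation in the Side Chain: Compound 2 to Compound 3

A few compounds are considered here, and "the series" means these few. Any claim that something is new, unique, unknown or untested is made for them only; others in the source may bear on it.

Compound 2 `COc1cc(OC)c2ccc(=O)oc2c1CC(C)(C)C=O` was tested in a functional assay on RAW264.7 cells (Mus musculus), with a stated time of 24 h (a higher number here means a weaker inhibitor, a lower number a stronger inhibitor), where compound 2 gives 12400 nM. Compound 1 `C=C(C)[C@H](O)[C@H](OCC)c1c(OC)ccc2ccc(=O)oc12` gives 12400 nM in this assay, so compound 2 stands level with compound 1 at the digits shown, within the scatter. Compound 3 `COc1cc(OC)c2ccc(=O)oc2c1C/C=C(\C)C=O` has not yet been measured; it differs from compound 2 by 2-formylprop-1-en-1-yl in place of 1-formyl-1-methylethyl on a saturated chain carbon bound to an aromatic carbon. Going by the values given here, no step between measured compounds covers such a change, so the step of a 1.6-fold lower number from compound 2 to compound 3 (0.19 log units; within the scatter) is expected to be small, towards somewhat stronger inhibition, and may not exceed the scatter. The estimate for compound 3 is 8000 nM, with a range from 3000 nM to 25000 nM.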

Compound 3, half-maximal inhibitory concentration: 28300 nM
Compound 3: the middle estimate sits 3.5-fold (0.55 log units) below what was measured; the measured number lies above the stated range.
By their numbers in this assay, from the lowest: compounds 1 and 2 (each within the scatter of the next); then compound 3.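

In this assay, putting 2-formylprop-1-en-1-yl in place of 1-formyl-1-methylethyl on a saturated chain carbon bound to an aromatic carbon gives a 2.3-fold higher number from compound 2 to compound 3 (0.36 log units; beyond the scatter), a modest move towards weaker inhibition. This first readable step shows that this place responds to the side chain, even with the heavy-atom count unchanged and one more double bond outside aromatic rings. Nothing at hand explains the rise. This single step does not separate the double bond from the altered branching of the chain. On these data alone, how an amine or a carboxylic acid in place of the formyl group would read remains open.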